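The source may hold more compounds than are shown below. What is called first, only, known or untested is meant among the compounds shown, and "the series" means these compounds.

Three compounds of a shared core have been measured in a functional assay on Huh-7 cells (Homo sapiens) for inhibition, read by sulforhodamine B assay; a higher number here means a weaker inhibitor, a lower number a stronger inhibitor:

compound 1 `C#CC(=O)N1C(c2cccc(F)c2)SC[C@@H]1C(=O)OCC`: 1400 nM
compound 2 `C#CC(=O)N1C(c2ccc(OC)cc2)SC[C@@H]1C(=O)OCC`: 1400 nM
compound 3 `C#CC(=O)N1C(CCCC)SC[C@@H]1C(=O)OCC`: 500 nM

Compound 3 stands lowest of the three numbers in this assay; the two aryl-bearing compounds give the same figure, and compound 1 as well as compound 2 sit beyond the scatter above compound 3. Among the compounds with values here, the one step that can be traced is a 2.8-fold lower number from compound 1 to compound 3 (0.45 log units; beyond the scatter), which shows that replacing an aromatic ring by the butyl chain on that ring carbon made the number smaller by a modest amount. Compound 4 `C#CC(=O)N1C(c2ccccc2)SC[C@@H]1C(=O)OCC` reverses this direction: phenyl in place of butyl on a saturated ring carbon. Within the data shown here, no step from compound 3 to an unsubstituted phenyl has been measured, but compound 2, with methoxyphenyl, gives the same value as compound 1 with its 3-fluorophenyl, so the two aryl groups examined so far behave alike relative to butyl. Compound 4 is therefore expected to return to the region of the aryl compounds, with a step of about a 2.6-fold higher number from compound 3 to compound 4 (0.41 log units; beyond the scatter). The estimate for compound 4 in this assay is 1300 nM, with a range from 600 nM to 3000 nM.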

Compound 4, half-maximal inhibitory concentration: 5300 nM
For compound 4 the middle estimate is 4.1-fold (0.61 log units) below the measured one; measured number above the stated range.
By their numbers in this assay, from the lowest: compound 3; then compounds 1 and 2 (each within the scatter of the next); then compound 4.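

In this assay, the aryl groups on this saturated ring carbon do not behave as one class: for the plain phenyl group there is an 11-fold higher number from compound 3 to compound 4 (1.03 log units; beyond the scatter), a large step where the one traced earlier from butyl to 3-fluorophenyl was modest. Substitution on the aromatic ring therefore counts, since putting hydrogen in place of methoxy gives a 3.8-fold higher number from compound 2 to compound 4 (0.58 log units; beyond the scatter) and putting hydrogen in place of fluoro gives a 3.8-fold higher number from compound 1 to compound 4 (0.58 log units; beyond the scatter). Both substituents thus stand on the same side of hydrogen in this small set, so the equal values of compound 1 and compound 2 do not mean that the aromatic ring tolerates any change without effect, and none of the three aryl compounds reaches the butyl compound.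

Nothing available explains why the plain phenyl group stands apart from the substituted ones or from butyl. On these data alone, it remains open whether a hydroxyl group or an amine on the aromatic ring would follow methoxy and fluoro, and whether a longer chain or a cyclohexyl group in place of butyl would move the number further down.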